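A few compounds are considered here, and "the series" means these few. Any claim that something is new, unique, unknown or untested is made for them only; others in the source may bear on it.

Of the compounds shown here, three have so far been tested in a functional assay on HT-29 cells (Homo sapiens) for inhibition; a lower number here means a stronger inhibitor, a higher number a weaker inhibitor. Compound 1, `CC(O)n1cnc2c(N)nc(I)nc21`, carries a 1-hydroxyethyl group on an aromatic nitrogen, and compound 2, `Nc1nc(I)nc2c1ncn2OCCO`, carries a 2-hydroxyethoxy group at the same place; their difference is 2-hydroxyethoxy in place of 1-hydroxyethyl on an aromatic nitrogen. In this assay compound 1 reaches only a limit of the assay, > 500000 nM. Compound 2 likewise gives only a limit, > 500000 nM. The step that the two limits leave unreadable from compound 1 to compound 2 therefore cannot be read. Compound 3, `CC(O)n1cnc2c(S)nc(F)nc21`, has a different core, and how its core differs from that of compound 1 is not broken down here. In this assay compound 3 also stops at a limit, > 500000 nM. All three values sit at the limit of > 500000 nM in this assay, at which 3 of the 3 values shown sit.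

Compound 4, `OCCOn1cnc2c(S)nc(F)nc21`, has not yet been measured. It differs from compound 3 by 2-hydroxyethoxy in place of 1-hydroxyethyl on an aromatic nitrogen, and the place is described word for word as for the first pair, so this is the same change. The expectation for compound 4 rests on the unreadable step that the two limits leave unreadable from compound 1 to compound 2 and on (the limit of > 500000 nM in this assay, at which 3 of the 3 values shown sit). The step to compound 4 is expected to be a number no higher from compound 3 to compound 4 (the limit leaves the size open). Compound 4 is expected to remain at a limit, estimated at 500000 nM, between 250000 nM and 1000000 nM.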

Compound 4, half-maximal inhibitory concentration: > 500000 nM
Compound 4: only a limit was reported; the forecaster's own chance of this, stated with the estimate: 90%; the middle value lies on the limit itself.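

Compound 3 and compound 4 both stop at a limit in this assay, so the step between them cannot be read, just as for compound 1 and compound 2. The compounds shown leave open whether 2-hydroxyethoxy or 1-hydroxyethyl gives the stronger inhibition, since every value sits at the same limit: the limit of > 500000 nM in this assay, at which 4 of the 4 values shown sit.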